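Methoxybenzyl in place of bromobenzyl on the triazole chromone

The source may hold more compounds than are shown below. What is called first, only, known or untested is meant among the compounds shown, and "the series" means these compounds.

Compound 1 `O=c1ccoc2cc(OCc3cn(Cc4ccccc4Cl)nn3)ccc12` gives 19700 nM in a functional assay on QGY7701 cells (Homo sapiens) for cytotoxicity, read by MTT assay, with a stated time of 48 h; on this read-out lower numbers stand for stronger inhibition and higher numbers for weaker inhibition. Compound 2 `O=c1ccoc2cc(OCc3cn(Cc4ccccc4Br)nn3)ccc12` differs from it by bromo in place of chloro on an aromatic carbon. In this assay compound 2 gives only > 100000 nM, which is a limit of the assay and not a number. The step of an at least 5.0-fold higher number from compound 1 to compound 2 (0.70 log units; beyond the scatter) therefore rests on a value that sits at the limit of > 100000 nM in this assay, at which 1 of the 2 values shown sits. Compound 3 `COc1ccc(Cn2cc(COc3ccc4c(=O)ccoc4c3)nn2)cc1` carries 4-methoxyphenyl in place of 2-bromophenyl on a saturated chain carbon bound to an aromatic nitrogen. Within the data shown here, no measured step exchanges a halogen for a methoxy group, so the one measured step gives only indirect guidance: a change of the substituent on this benzyl ring moved the number by at least the size of that step, and the 4-methoxyphenyl group brings one hydrogen-bond acceptor where the 2-bromophenyl group brought none. Compound 3 is therefore expected to land near 40000 nM, within 10000 nM to 160000 nM, meaning an expected step of an at least 2.5-fold lower number from compound 2 to compound 3 (0.39 log units; beyond the scatter), with a real chance that this assay again reports only a limit.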

Compound 3, half-maximal inhibitory concentration: 56600 nM
Compound 3: middle estimate off by 1.4-fold (0.15 log units), on the low side, and the stated range covers the measured number.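

With the 4-methoxyphenyl group on the saturated chain carbon bound to an aromatic nitrogen, this position now has a second exact reading in this assay, and the exchange for the 2-chlorophenyl group gives a 2.9-fold higher number from compound 1 to compound 3 (0.46 log units; beyond the scatter). Against the 2-bromophenyl group the result is only an at least 1.7-fold lower number from compound 2 to compound 3 (0.24 log units; that floor lies within the scatter), so this comparison fixes a floor and leaves the true size of the gap unknown. Compound 2 remains a limit and not a number, and that step rests on it: the limit of > 100000 nM in this assay, at which 1 of the 3 values shown sits.

The compounds shown leave open whether the methoxy group itself or its location on the phenyl ring goes with the step from the 2-chlorophenyl group. They also leave open how an amine or a carboxylic acid on this benzyl ring would read in this assay.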